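This account rests on a few compounds, and the source may have more. Where it says the series, first, only, none or still open, it means among the compounds named here.

In a functional assay on HT-29 cells (Homo sapiens) for antiproliferative activity, read by sulforhodamine B assay, with a stated time of 48 h (on this read-out higher numbers stand for weaker inhibition and lower numbers for stronger inhibition), compound 1 `CCCN1CCN(c2ccc(S(=O)(=O)Oc3ccccc3C)cc2)C1=O` reaches only the limit > 100000 nM and gives no number. Compound 2 `CCCN1CCN(c2ccc(S(=O)(=O)Oc3cc(Cl)c(Cl)cc3Cl)cc2)C1=O` gives 19000 nM and compound 3 `CCCN1CCN(c2ccc(S(=O)(=O)Oc3cccc(C)c3)cc2)C1=O` gives 65000 nM as the higher of the two real numbers. Compound 4 `CCCN1CCN(c2ccc(S(=O)(=O)Oc3cccc(Cl)c3)cc2)C1=O` differs from compound 3 by chloro in place of methyl on an aromatic carbon with chloro in place of methyl on an aromatic carbon. Going by the values given here, the steps that bear on it both involve the 2,4,5-trichlorophenyl group: a 3.4-fold higher number from compound 2 to compound 3 (0.53 log units; beyond the scatter) is modest and an at least 5.2-fold lower number from compound 1 to compound 2 (0.72 log units; beyond the scatter) is at least modest. A single chloro should bring only part of that change, so a small move to a lower number is expected in this assay, probably within the scatter. The estimated step is a 1.6-fold lower number from compound 3 to compound 4 (0.21 log units; within the scatter) in all. Compound 4 is expected at 40000 nM with a range of 18000 nM to 90000 nM on this read-out.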

Compound 4, half-maximal inhibitory concentration: 13000 nM
Estimate against measurement, compound 4: 3.1-fold (0.49 log units) above; the measured number lies below the stated range.
By their numbers in this assay, from the lowest: compounds 4 and 2 (each within the scatter of the next); then compound 3. At a limit, above all of these: compound 1.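

In this assay, going by these compounds alone, chloro in place of methyl on this aromatic carbon counts for more than the earlier compounds suggested: a 5.0-fold lower number from compound 3 to compound 4 (0.70 log units; beyond the scatter). A single chloro on the ring does as well as three, since 3-chlorophenyl and 2,4,5-trichlorophenyl cannot be told apart: a 1.5-fold lower number from compound 2 to compound 4 (0.16 log units; within the scatter). The step of an at least 7.6-fold lower number from compound 1 to compound 4 (0.88 log units; beyond the scatter) is only a floor, as compound 1 reaches a limit: the limit of > 100000 nM in this assay, at which 1 of the 4 values shown sits.

Whether this gain belongs to chloro alone stays open, as fluoro, methoxy or a nitrile at this position are not among the compounds shown. Also open, going by these compounds, is whether a longer chain in place of the propyl group would shift these numbers.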